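The compounds below may be only part of what the source reports. "The series", "measured", "known", "first", "only" and "open" are said of these compounds alone.

Compound 1 `Cc1ccc(-c2csc(NC(=O)COc3ccccc3C(C)C)n2)cc1` gives 56800 nM in a functional assay on MDA-MB-468 cells (Homo sapiens) for cytotoxicity, read by trypan blue exclusion, with a stated time of 48 h; a lower number here means a stronger inhibitor, a higher number a weaker inhibitor. Compound 2 `CC(C)c1ccccc1OCC(=O)Nc1nc(-c2ccc(Br)cc2)cs1` carries bromo in place of methyl on an aromatic carbon, and in this assay compound 2 gives 50100 nM, a step of a 1.1-fold lower number from compound 1 to compound 2 (0.05 log units; within the scatter). Compound 3 `Cc1ccc(OCC(=O)Nc2nc(-c3ccc(C)cc3)cs2)cc1` is built on a different core, and the difference between the two cores is not broken down here; in this assay compound 3 gives 37100 nM. Compound 4 `Cc1ccc(OCC(=O)Nc2nc(-c3ccc(Br)cc3)cs2)cc1` differs from compound 3 by bromo in place of methyl on an aromatic carbon, the same change as before, at the same place. The step to compound 4 is expected to be a 1.1-fold lower number from compound 3 to compound 4 (0.04 log units; within the scatter), resting on the earlier matched pair, because a 1.1-fold lower number from compound 1 to compound 2 (0.05 log units; within the scatter) sat within the scatter. Compound 4 is therefore estimated at 34000 nM. For compound 4 the expected range runs from 15000 nM to 80000 nM.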

Compound 4, half-maximal inhibitory concentration: 44500 nM
The estimate for compound 4 lay 1.3-fold (0.12 log units) below the measured number, and the stated range covers the measured number.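

On the core of compound 3, bromo in place of methyl gives a 1.2-fold higher number from compound 3 to compound 4 (0.08 log units; within the scatter) in this assay, so on this core too the step stays within the scatter. The two steps agree within the scatter of such a comparison: the same change on two cores in this assay, a 1.1-fold lower number (0.05 log units; within the scatter) from compound 1 to compound 2 and a 1.2-fold higher number (0.08 log units; within the scatter) from compound 3 to compound 4, 1.4-fold (0.13 log units) apart, within the scatter of two such steps. Among the compounds shown here, this shows that the change carried from one core to the other without a readable difference, but it rests on only two pairs and cannot reveal an effect smaller than the scatter or show that the result would hold on a third core.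

On these data alone, it remains open whether another group at this place, such as an amine, a carboxylic acid or a methoxy group, would give a step beyond the scatter.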